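A few compounds are considered here, and "the series" means these few. Any claim that something is new, unique, unknown or untested is made for them only; others in the source may bear on it.

Measured compounds:
- Compound 1 `Cc1nc(C(NC(=O)C(=O)Nc2ccc(F)c(F)c2)C2CCCCN2)sc1CO` — in an ADME assay on TZM-b1 cells (Homo sapiens) for cytotoxicity, read by XTT assay, with a stated time of 3 days (on this read-out higher numbers stand for lower toxicity in this test and lower numbers for higher toxicity in this test), compound 1 gives > 87000 nM, which is a limit of the assay and not a number.
- Compound 2 `CC(=O)N1CCCCC1C(NC(=O)C(=O)Nc1ccc(Cl)cc1)c1nc(C)c(CCO)s1` — in this assay compound 2 gives > 84000 nM, likewise a limit of the assay rather than a number.

Among the compounds with values here, compound 1 therefore stands at a limit in this assay, and the only other value shown stands at a limit as well: the limit of > 87000 nM in this assay, at which 1 of the 2 values shown sits, and (the limit of > 84000 nM in this assay, at which 1 of the 2 values shown sits). Compound 3 `Cc1nc(C(NC(=O)C(=O)NC2CCCCCC2)C2CCCCN2)sc1CO` is the compound not yet measured; it differs from compound 1 by cycloheptyl in place of 3,4-difluorophenyl on an amide-type nitrogen. Within the data shown here, no measured pair shows this change, so nothing direct tells how it moves the read-out. With both measured values sitting at limits, the step from compound 1 to compound 3 is expected to be none beyond the scatter in this assay, that is a step that the limit leaves unreadable from compound 1 to compound 3 as an expectation. Compound 3 is accordingly estimated at 90000 nM, within 30000 nM to 300000 nM, and most likely reported as a limit once more.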

Compound 3, half-maximal cytotoxic concentration: > 90000 nM
Compound 3 was reported as a limit (the forecaster's own chance of this, stated with the estimate: 80%); the middle value lies on the limit itself.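

Compound 1 and compound 3 are both reported only as limits in this assay, and no step can be read between them. The compounds shown leave open whether cycloheptyl in place of 3,4-difluorophenyl moves the half-maximal cytotoxic concentration at all, and at what concentration any of them would reach it.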